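This account rests on a few compounds, and the source may have more. Where it says the series, first, only, none or still open, it means among the compounds named here.

Compound 1 `O=C(C[C@H]1CC[C@]2(CC1)OO[C@]1(O2)C2CC3CC(C2)CC1C3)N1CCNCC1` gives 25 L/kg
Compound 2 `O=C(C[C@H]1CC[C@]2(CC1)OO[C@]1(O2)C2CC3CC(C2)CC1C3)N1CCC(O)CC1` gives 36 L/kg
Compound 3 `NC1CCN(C(=O)C[C@H]2CC[C@]3(CC2)OO[C@]2(O3)C3CC4CC(C3)CC2C4)CC1` gives 19 L/kg

These values come from an in vivo ADME assay on the whole organism (strain Sprague-Dawley) for pharmacokinetics, with Rattus norvegicus as the target, given by the intravenous route (on this read-out higher numbers stand for wider distribution into tissues and lower numbers for narrower distribution), and compound 3 sits within the scatter of the other two. The steps reaching it are a 1.3-fold lower number from compound 1 to compound 3 (0.12 log units; within the scatter) and a 1.9-fold lower number from compound 2 to compound 3 (0.28 log units; within the scatter) and both are small.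

Compound 4 `CC(C)(N)CNC(=O)CC[C@H]1CC[C@]2(CC1)OO[C@]1(O2)C2CC3CC(C2)CC1C3` is not yet measured. It carries ((2-amino-2-methylpropyl)carbamoyl)methyl in place of (4-aminopiperidin-1-yl)carbonyl on a saturated chain carbon bound to a saturated ring carbon. Among the measured compounds shown here, every measured compound keeps a ring on the carbonyl carbon, so no measured step shows what opening it does, and the guide is loose. Still, nothing beyond the scatter is expected in this assay for this change. The expected size is a 1.1-fold higher number from compound 3 to compound 4 (0.02 log units; within the scatter) on this estimate. Compound 4 is estimated at 20 L/kg with an expected range from 10 L/kg to 40 L/kg in this read-out.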

Compound 4, volume of distribution: 12 L/kg
Estimate against measurement, compound 4: 1.7-fold (0.22 log units) above; the measured number falls inside the stated range.
By their numbers in this assay, from the lowest: compounds 4, 3, 1 and 2 (each within the scatter of the next, the first and the last beyond it).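

In this assay the first open chain at this place, ((2-amino-2-methylpropyl)carbamoyl)methyl, gives a 1.6-fold lower number from compound 3 to compound 4 (0.20 log units; within the scatter) and so stays close to the 4-aminopiperidin-1-yl ring it replaces. Against the other two rings the same chain gives a 2.1-fold lower number from compound 1 to compound 4 (0.32 log units; beyond the scatter) and a 3.0-fold lower number from compound 2 to compound 4 (0.48 log units; beyond the scatter) and these modest steps are the first in this set to pass the scatter. Nothing shown gives a cause for these steps. Still open, going by these compounds, is whether a plain 2-aminoethyl chain, or a carboxylic acid in place of the amine, would stay as close to compound 3.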